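One Stereocentre Redrawn: From Compound 1 to Compound 3

This account rests on a few compounds, and the source may have more. Where it says the series, first, only, none or still open, it means among the compounds named here.

Compound 1, `CC#C[C@H]1CN(S(=O)(=O)c2ccc(N)nc2)CCN1c1ccc([C@@](O)(CO)C(F)(F)F)cc1`, was tested in an assay on cells (Hepatocyte) for inhibition of glucokinase regulatory protein (Mus musculus), with stated times of 20 min and 40 min (on this read-out lower numbers stand for an effect already at smaller amounts and higher numbers for an effect only at larger amounts of compound), and gave 89 nM. Within the data shown here, the only other measured compound, compound 2, `CC#C[C@H]1CN(S(=O)(=O)c2ccc(N)nc2)CCN1c1ccc(C(O)(C(F)(F)F)C(F)(F)F)cn1`, gave 421 nM in this assay. Among the measured compounds shown here, on these two numbers compound 1 stands lowest, and the gap to compound 2 lies beyond the usual scatter; with only two compounds no broader pattern can be drawn from them.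

Compound 3, `CC#C[C@H]1CN(S(=O)(=O)c2ccc(N)nc2)CCN1c1ccc([C@](O)(CO)C(F)(F)F)cc1`, has not yet been measured. It keeps every atom and bond of compound 1 and differs from it only in configuration: the two compounds have the same atoms and bonds and differ only in configuration as drawn: 1 of 2 stereo elements differ; a stereocentre at a saturated chain carbon is drawn R in compound 1 and S in compound 3. For the measured compounds named here, no measured pair here shows what such a change of configuration does in this assay, so the size of the step is open. When only one stereocentre is redrawn, a moderate loss is expected more often than a gain, but either outcome remains possible.

The estimate for compound 3 in this assay is therefore 220 nM, with a range of 60 nM to 900 nM. This corresponds to an expected step of a 2.5-fold higher number from compound 1 to compound 3 (0.39 log units; beyond the scatter), weaker than compound 1 but not with confidence beyond the scatter.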

Compound 3, half-maximal effective concentration: 98 nM
Compound 3: middle estimate off by 2.2-fold (0.35 log units), on the high side; low and high end bracket the measured number.
By their numbers in this assay, from the lowest: compounds 1 and 3 (each within the scatter of the next); then compound 2.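

In this assay, redrawing this stereocentre gives a 1.1-fold higher number from compound 1 to compound 3 (0.04 log units; within the scatter). Among these compounds, this is the first pair here that isolates a change of configuration, and it shows no difference that can be told from the scatter. The step can be read as a test of configuration alone at this saturated chain carbon, with no change of group to confound it: the fact that compounds 1 and 3 differ only in the configuration as drawn. On this read-out the forms drawn R and S at this carbon therefore cannot be told apart, although that finding holds only for this one pair and says nothing about other stereocentres or other assays.

The compounds shown leave open whether the two configurations would remain this close with a carboxylic acid, an amine or a longer chain at this saturated chain carbon. They also leave open what redrawing the second stereo element would do, since it is drawn the same way in compound 1 and compound 3, and whether a change there would matter more in this assay.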